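Aryl reinstated in place of the ethoxypropenyl chain

This account rests on a few compounds, and the source may have more. Where it says the series, first, only, none or still open, it means among the compounds named here.

Measured so far:
compound 1 `COC(=O)/C=C/c1cccc(N(Cc2ccc(-c3ccc(F)c(F)c3)cc2)C(=O)C2CCCCC2)c1` — 72 nM
compound 2 `CCOC/C=C/c1ccc(CN(C(=O)C2CCCCC2)c2cccc(/C=C/C(=O)OC)c2)cc1` — 198000 nM

In an assay on isolated protein with Bile acid receptor (Homo sapiens) as the target (a lower number here means that less compound is needed, a higher number that more compound is needed for the effect), compound 2 gives 198000 nM, the highest of the two numbers; the nearest, compound 1, gives 72 nM. Compound 3 `COC(=O)/C=C/c1cccc(N(Cc2ccc(-c3cc(Cl)ccc3OC)cc2)C(=O)C2CCCCC2)c1` differs from compound 2 by 5-chloro-2-methoxyphenyl in place of 3-ethoxyprop-1-en-1-yl on an aromatic carbon. For the measured compounds named here, the single step that bears on this is a 2800-fold higher number from compound 1 to compound 2 (3.44 log units; beyond the scatter), in which an aryl group on this same carbon gave way to the ethoxypropenyl chain; compound 3 puts a different aryl group back. A large drop in this assay is therefore expected, a 1300-fold lower number from compound 2 to compound 3 (3.12 log units; beyond the scatter). Compound 3 is estimated at 150 nM (range 25 nM to 1500 nM).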

Compound 3, half-maximal effective concentration: 233 nM
Estimate against measurement, compound 3: 1.6-fold (0.19 log units) below; the range from low to high includes it.
By their numbers in this assay, from the lowest: compound 1; then compound 3; then compound 2.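

In this assay the step of an 850-fold lower number from compound 2 to compound 3 (2.93 log units; beyond the scatter) shows that the low numbers at this position do not depend on one particular aryl group, since 5-chloro-2-methoxyphenyl also restores them. The two aryl groups are still not interchangeable: a 3.2-fold higher number from compound 1 to compound 3 (0.51 log units; beyond the scatter) is a modest step but lies beyond the scatter. No measurement at hand explains either step.

Open, as far as these compounds go, is how an unsubstituted phenyl or a pyridine ring would read on this carbon. Also open, from the compounds shown here alone, is whether the chlorine or the methoxy alone accounts for the gap to compound 1.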